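Series notes: saturated and fluorinated arms on the shared core

This account rests on a few compounds, and the source may have more. Where it says the series, first, only, none or still open, it means among the compounds named here.

Three compounds carry the same core and differ only in the group on a saturated chain carbon bound to an aromatic carbon. Compound 1 `O=C(O)c1ccccc1-c1ccc(CCc2ncc(CC3CCCCC3)[nH]2)cc1` gives 7.3 nM in an in vitro functional assay on cells for agonist activity at Bombesin receptor subtype-3 (Mus musculus), read by luminescence and calcium flux; on this read-out lower numbers stand for an effect already at smaller amounts and higher numbers for an effect only at larger amounts of compound. Compound 2 `O=C(O)c1ccccc1-c1ccc(CCc2ncc(CC3CCC3)[nH]2)cc1` gives 7.1 nM in this assay, with a 1.0-fold lower number from compound 1 to compound 2 (0.01 log units; within the scatter). Compound 3 `O=C(O)c1ccccc1-c1ccc(CCc2ncc(Cc3ccccc3F)[nH]2)cc1` gives 9.5 nM in this assay; this is the highest of the three numbers, but the steps of a 1.3-fold higher number from compound 1 to compound 3 (0.11 log units; within the scatter) and a 1.3-fold higher number from compound 2 to compound 3 (0.13 log units; within the scatter) are both within the scatter, so no ordering among the three is claimed.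

Compound 4 `CC(C)(C)Cc1cnc(CCc2ccc(-c3ccccc3C(=O)O)cc2)[nH]1` has not been measured in this assay. The change from compound 3 is tert-butyl in place of 2-fluorophenyl on a saturated chain carbon bound to an aromatic carbon. Among the measured compounds shown here, the steps that bear on it are those that exchange the 2-fluorophenyl for a saturated group: a 1.3-fold higher number from compound 1 to compound 3 (0.11 log units; within the scatter) and a 1.3-fold higher number from compound 2 to compound 3 (0.13 log units; within the scatter), both within the scatter. Neither a six-membered saturated ring nor a four-membered one moved the number beyond the scatter against the 2-fluorophenyl, and a tert-butyl group without ring is expected to behave similarly. The expected step is a 1.2-fold lower number from compound 3 to compound 4 (0.07 log units; within the scatter), which is no change beyond the scatter. Compound 4 is therefore estimated at 8 nM, with a range from 3 nM to 22 nM.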

Compound 4, half-maximal effective concentration: 6.3 nM
For compound 4 the middle estimate is 1.3-fold (0.10 log units) above the measured one, and the stated range covers the measured number.
By their numbers in this assay, from the lowest: compounds 4, 2, 1 and 3 (each within the scatter of the next).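

Notes on the group on a saturated chain carbon bound to an aromatic carbon: in this assay, tert-butyl, which has no ring, gives a 1.5-fold lower number from compound 3 to compound 4 (0.18 log units; within the scatter) against 2-fluorophenyl, a 1.1-fold lower number from compound 2 to compound 4 (0.05 log units; within the scatter) against cyclobutyl and a 1.2-fold lower number from compound 1 to compound 4 (0.06 log units; within the scatter) against cyclohexyl. A ring in this group is therefore not needed to stay within the scatter of the three earlier compounds, and the exchange of 2-fluorobenzyl for neopentyl, which removes the aromatic ring and the fluorine and leaves 4 heavy atoms in place of 7, produces no step beyond the scatter. The four compounds now cover an aromatic ring, two saturated rings and a ringless group at this place without any separation in this read-out, and nothing available on these compounds accounts for that flat response.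

What an amine, a hydroxyl group or a carboxylic acid would do at this place remains open, since all four groups shown are carbon-based, with fluorine as the only other element. Also open, as far as these compounds go, is whether a single methyl group or a longer chain would stay within the same scatter.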